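A few compounds are considered here, and "the series" means these few. Any claim that something is new, unique, unknown or untested is made for them only; others in the source may bear on it.

Compound 3 `Cc1c(C(=O)/C=C/c2ccc(Cl)c(Cl)c2)[n+]([O-])c2ccccc2[n+]1[O-]` holds the highest of the three numbers recorded in a functional assay on HL-60 cells (Homo sapiens) for cytotoxicity, with a stated time of 48 h (on this read-out higher numbers stand for lower toxicity in this test and lower numbers for higher toxicity in this test), where compound 3 gives 27000 nM. Its two neighbours sit a little lower: in this assay compound 1 `COc1ccc(/C=C/C(=O)c2c(C)[n+]([O-])c3ccccc3[n+]2[O-])cc1` gives 16000 nM, and compound 2 `Cc1c(C(=O)/C=C/c2ccc(Cl)cc2)[n+]([O-])c2ccccc2[n+]1[O-]` gives 11000 nM. Among the compounds with values here, the measured steps between these three show a 1.7-fold higher number from compound 1 to compound 3 (0.23 log units; within the scatter), a 2.5-fold higher number from compound 2 to compound 3 (0.39 log units; beyond the scatter) and a 1.5-fold lower number from compound 1 to compound 2 (0.16 log units; within the scatter), so the only step that clears the scatter is the one that adds a second chloro, and even that one is modest.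

Compound 4 `Cc1ccc(/C=C/C(=O)c2c(C)[n+]([O-])c3ccccc3[n+]2[O-])cc1` differs from compound 3 in one place: 4-methylphenyl in place of 3,4-dichlorophenyl on a double-bonded chain carbon bound to a double-bonded chain carbon. Within the data shown here, two measured steps bear on this change. The step from compound 2 to compound 3 is run in reverse when one chloro is taken away, and the step from compound 1 to compound 3 shows what a swap from a singly substituted phenyl to the dichlorophenyl did. Both point the same way, towards a lower number, and neither was large. Compound 4 is therefore expected to move back towards the region of compounds 1 and 2, with an estimated step of a 2.1-fold lower number from compound 3 to compound 4 (0.32 log units; beyond the scatter). For compound 4 the estimate in this assay is 13000 nM, within a range of 5000 nM to 35000 nM.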

Compound 4, half-maximal cytotoxic concentration: 4100 nM
Compound 4: middle estimate off by 3.2-fold (0.50 log units), on the high side; measured number outside the range, below it.
By their numbers in this assay, from the lowest: compound 4; then compounds 2, 1 and 3 (each within the scatter of the next, the first and the last beyond it).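

In this assay, the result shows that this position can take the number below the level of compounds 1 and 2, not only back towards it: the step of a 6.6-fold lower number from compound 3 to compound 4 (0.82 log units; beyond the scatter) is accompanied by a 2.7-fold lower number from compound 2 to compound 4 (0.43 log units; beyond the scatter) and a 3.9-fold lower number from compound 1 to compound 4 (0.59 log units; beyond the scatter), so the 4-methylphenyl group separates from both singly substituted neighbours. The earlier swap of chloro for methoxy had produced no step beyond the scatter, whereas methyl in place of either group does, and compound 4 is the only one of the four whose steps to all the others lie beyond it, giving it the lowest number and the highest toxicity in this test. No supporting measurement here explains why this change has this effect.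

The compounds shown leave open whether the lower number belongs to methyl specifically, or would also follow from a longer chain such as ethyl or from an amine on the same aromatic carbon. They also leave open whether a phenyl ring carrying only hydrogen would fall with compound 4 or with compounds 1 and 2.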